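Swapping Chlorine for Bromine on the Phenyl Ring

The compounds below may be only part of what the source reports. "The series", "measured", "known", "first", "only" and "open" are said of these compounds alone.

Of the compounds shown here, three built on one shared core have been tested in a functional assay on SR cells (Homo sapiens) for inhibition, read by sulforhodamine B assay, with a stated time of 48 h, tested at 10 uM; on this read-out higher numbers stand for more inhibition at the one concentration tested (going by the name of the read-out) and lower numbers for less inhibition. Compound 1 `O=Cc1ccc(-c2cn3ccnc3c(-c3ccc4ncn(C5CCCCC5)c4c3)n2)cc1` carries a formyl group on its phenyl ring and gives 47.5%. Compound 2 `CC(=O)c1ccc(-c2cn3ccnc3c(-c3ccc4ncn(C5CCCCC5)c4c3)n2)cc1`, with an acetyl group in that place, gives 23.6%, and compound 3 `Clc1ccc(-c2cn3ccnc3c(-c3ccc4ncn(C5CCCCC5)c4c3)n2)cc1`, with a chloro group there, gives 18.5%. Compound 3 thus has the lowest of the three numbers: its gap to compound 2 is within the scatter, while the step of a number 29 percentage points lower from compound 1 to compound 3 (beyond the scatter) and the step of a number 23.9 percentage points lower from compound 1 to compound 2 (beyond the scatter) both lie beyond it. The step of a number 5.1 percentage points lower from compound 2 to compound 3 (within the scatter) shows that exchanging acetyl for chloro made no difference the assay can resolve.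

Compound 4 `Brc1ccc(-c2cn3ccnc3c(-c3ccc4ncn(C5CCCCC5)c4c3)n2)cc1` differs from compound 3 in one place: bromo in place of chloro on an aromatic carbon. Among the compounds with values here, no measured step swaps one halogen for another, so there is no direct precedent. Within the data shown here, the only step that touches the chloro group, from compound 2 to compound 3, lay within the scatter, and the present swap occurs on that same aromatic carbon. The expectation is therefore a step of about a number 1.5 percentage points higher from compound 3 to compound 4 (within the scatter), that is, none beyond the scatter. Compound 4 is estimated at 20%, with a likely range from 8% to 34%.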

Compound 4, a percentage reported as inhibition, at one concentration (the size of the read-out at that concentration, not a potency): 60.7%
Beside the measured number, compound 4's estimate is 40.7 percentage points below it; the measured number lies above the stated range.
By their numbers in this assay, from the lowest: compounds 3 and 2 (each within the scatter of the next); then compound 1; then compound 4.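

In this assay, within the data shown here, this aromatic carbon turns out to be far more sensitive than the earlier compounds suggested: exchanging one halogen for another gives a number 42.2 percentage points higher from compound 3 to compound 4 (beyond the scatter), whereas exchanging acetyl for chloro gave only a number 5.1 percentage points lower from compound 2 to compound 3 (within the scatter). The bromo group also separates compound 4 from the two other compounds, with a number 37.1 percentage points higher from compound 2 to compound 4 (beyond the scatter) and a number 13.2 percentage points higher from compound 1 to compound 4 (beyond the scatter), so compound 4 now has the highest number of the four, and formyl no longer holds the top place. Chloro and bromo are both single, uncharged atoms, so this series shows that a very small change in structure at this carbon can produce a large step, though no measurement available here accounts for the gap between these two groups.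

As far as these compounds go, it remains open whether this rise is particular to bromo or whether iodo, fluoro, an amine or a carboxylic acid on the same carbon would also read high. From the compounds shown here alone, these numbers each come from one concentration, so how compound 4 compares with the others in potency also remains open.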